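Anilino for phenylcarbamoyl: the step from compound 1 to compound 4

The compounds below may be only part of what the source reports. "The series", "measured", "known", "first", "only" and "open" are said of these compounds alone.

Measured compounds in a physicochemical assay for solubility, read by LC-MS, in phosphate buffer, with a stated time of 24 h, at pH 7.4; a higher number here means a more soluble compound, a lower number a less soluble compound:
- compound 1 `O=C(Nc1ccccc1)c1cnc(NCc2c(F)ccc3c2CCO3)n2cnnc12` gives < 1000 nM, a limit of the assay.
- compound 2 `CN(C)Cc1ccc2c(c1)CN(c1cnc(NCc3c(F)ccc4c3CCO4)c3cn[nH]c(=O)c13)C2=O` gives 174000 nM.
- compound 3 `Cc1nc(CN(C)C)ccc1-c1cnc(NCc2c(F)ccc3c2CCO3)c2cn[nH]c(=O)c12` gives > 1000000 nM, a limit of the assay.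

Compound 1 sits at the low end of the three values shown, at the limit of < 1000 nM in this assay, at which 1 of the 3 values shown sits. Compound 3 sits at the other end, at the limit of > 1000000 nM in this assay, at which 1 of the 3 values shown sits. Compound 2 stands between them with a number rather than a limit. No two of the measured compounds differ in only one place, so no measured step can be read off here.

Compound 4 `Fc1ccc2c(c1CNc1ncc(Nc3ccccc3)c3nncn13)CCO2` differs from compound 1 in one place: anilino in place of phenylcarbamoyl on an aromatic carbon. The change keeps one hydrogen-bond donor and one hydrogen-bond acceptor, removes one double bond outside aromatic rings and two heavy atoms, and leaves the rest of the shared core untouched. Because compound 1 gives only a limit at the limit of < 1000 nM in this assay, at which 1 of the 3 values shown sits, the size of any step cannot be fixed from above; the expected step of a number no lower from compound 1 to compound 4 (the limit leaves the size open) is none beyond the usual scatter. Compound 4 is therefore expected to give 1000 nM, within a range from 300 nM to 5000 nM, and it is quite possible that this assay again reports only a limit.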

Compound 4, solubility: 3000 nM
Estimate against measurement, compound 4: 3.0-fold (0.48 log units) below; the range from low to high includes it.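

For the compounds shown here, on an aromatic carbon of the shared core, the exchange of phenylcarbamoyl for anilino gives in this assay an at least 3.0-fold higher number from compound 1 to compound 4 (0.47 log units; beyond the scatter), the only step in this set that can be read, and it shows that this position alone can move the read-out. With the rest of the core untouched, compound 4 gives 3000 nM, a number rather than a limit. The step sets a floor and no fixed size, since compound 1 stands at a limit of the assay: the limit of < 1000 nM in this assay, at which 1 of the 4 values shown sits.

A single pair cannot separate the loss of the carbonyl from the shorter link to the phenyl ring, and a benzylamino or a phenylacetyl group at this position would be needed to tell them apart. On these data alone, how a tertiary amine or a carboxylic acid on the anilino ring would read in this assay also remains open.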